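The compounds below may be only part of what the source reports. "The series", "measured", "known", "first", "only" and "open" are said of these compounds alone.

Among the measured compounds shown here, in an ADME assay for pharmacokinetics (on this read-out higher numbers stand for a longer-lived compound and lower numbers for a shorter-lived compound), compound 1 `CO[C@H]1C(=O)N2C(C(=O)OCc3ccc(C(=O)O)cc3)=C(COC(C)=O)CS(=O)(=O)[C@H]12` gives 5 h, the lower of the two numbers so far, and compound 2 `CC[C@H]1C(=O)N2C(C(=O)OCc3ccc(C(=O)O)cc3)=C(COC(C)=O)CS(=O)(=O)[C@H]12` gives 40 h. Compound 3 `COC(=O)c1ccc(COC(=O)C2=C(COC(C)=O)CS(=O)(=O)[C@@H]3[C@@H](OC)C(=O)N23)cc1` keeps the core of compound 1 with one change: methyl in place of hydrogen on an oxygen next to a carbonyl group, turning carboxy into methoxycarbonyl. For the measured compounds named here, the only measured step, an 8.0-fold higher number from compound 1 to compound 2 (0.90 log units; beyond the scatter), swapped methoxy for ethyl at another place, so it offers little guidance here. The expected step, no change at the digits printed from compound 1 to compound 3 (within the scatter), therefore stays within the scatter. The estimate for compound 3 is 5 h, with an expected range of 2 h to 12 h.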

Compound 3, half-life: < 5 h
Compound 3: no number, only a limit (the forecaster's own chance of this, stated with the estimate: 3%); the middle value lies on the limit itself.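

In this assay compound 3 gives < 5 h, which is a limit of the assay and not a number. This is the first change shown at the carboxy group: methoxycarbonyl in its place gives a number no higher from compound 1 to compound 3 (the limit leaves the size open), though the size of this step cannot be read. The earlier step, methoxy to ethyl, was made at another place and said nothing about this one.

As far as these compounds go, how far compound 3 falls short of compound 1 stays open. So does whether an ethoxycarbonyl or a carboxamide group at this place would give a readable number.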